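Branching the side chain on a thioester relative

The compounds below may be only part of what the source reports. "The series", "measured", "known", "first", "only" and "open" are said of these compounds alone.

Compound 1 `CCCC(=O)C1=C(C)NC(=O)NC1c1ccco1` and compound 2 `CC1=C(C(=O)CC(C)C)C(c2ccco2)NC(=O)N1` share a core and differ by methyl in place of hydrogen on a saturated chain carbon bound to two saturated chain carbons. In an assay on membranes from HeLa cells for displacement of a labelled ligand from adenosine receptor A3 (Homo sapiens), read by scintillation counting, with a stated time of 180 min, tested at 1 uM (a lower number here means less inhibition, a higher number more inhibition at the concentration tested (going by the name of the read-out)), compound 1 gives 1%, while compound 2 gives 31%, which is a number 30 percentage points higher from compound 1 to compound 2 (beyond the scatter). Compound 3 `CCSC(=O)C1=C(C)NC(=O)NC1c1cccs1` gives 1% in this assay, level with compound 1; how its core differs from that of compound 1 is not broken down here. Compound 4 `CC1=C(C(=O)SC(C)C)C(c2cccs2)NC(=O)N1` differs from compound 3 by methyl in place of hydrogen on a saturated chain carbon bound to a saturated chain carbon and a sulfur. This is the same kind of change as that from compound 1 to compound 2, though the carbon that gains the methyl is bound to a saturated chain carbon and a sulfur rather than to two saturated chain carbons. The core of compound 3 and the place of the change both differ from those of compound 1, so the expected step, a number 17 percentage points higher from compound 3 to compound 4 (beyond the scatter), is set smaller than a number 30 percentage points higher from compound 1 to compound 2 (beyond the scatter). Compound 4 is estimated at 18%, with a range from 0% to 45%.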

Compound 4, a percentage reported as inhibition, at one concentration (the size of the read-out at that concentration, not a potency): 1%
Beside the measured number, compound 4's estimate is 17 percentage points above it; low and high end bracket the measured number.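

In this assay, the change does not repeat on the second core: no change at the digits printed from compound 3 to compound 4 (within the scatter). Within the data shown here, the methyl in place of hydrogen therefore does not carry over from one core to the other with the same size of step: the same change on two cores in this assay, a number 30 percentage points higher (beyond the scatter) from compound 1 to compound 2 and no change at the digits printed (within the scatter) from compound 3 to compound 4, 30 percentage points apart, beyond the scatter of two such steps With only one pair on each core, this does not show which of the differences between the two cores matters, or what the same change would do on any further core.

The compounds shown leave open whether a longer chain, such as butyl, or a tert-butyl group would raise the inhibition on the core of compound 3. They also leave open how either group would behave on the core of compound 1.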